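Methoxy count on the benzylamine arm and growth inhibition

The compounds below may be only part of what the source reports. "The series", "measured", "known", "first", "only" and "open" are said of these compounds alone.

Measured compounds:
compound 1, `Nc1cc(N)c2nc(-c3ccccc3)c(Oc3ccc(Cl)c(Cl)c3)nc2c1`, 87100 nM
compound 2, `COc1ccc(CNc2nc3cc(N)cc(N)c3nc2-c2ccccc2)cc1OC`, 26900 nM
compound 3, `COc1cc(CNc2nc3cc(N)cc(N)c3nc2-c2ccccc2)cc(OC)c1OC`, 10700 nM

In a functional assay on UACC-257 cells (Homo sapiens) for inhibition, read by sulforhodamine B assay, with a stated time of 48 h (a lower number here means a stronger inhibitor of growth, a higher number a weaker inhibitor of growth), compound 1 gives 87100 nM, compound 2 gives 26900 nM and compound 3 gives 10700 nM. Compound 2 therefore stands second highest of the three numbers; its nearest neighbour is compound 3, its furthest compound 1, and both gaps lie beyond the scatter.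

Compound 4, `COc1ccc(CNc2nc3cc(N)cc(N)c3nc2-c2ccccc2)cc1`, is not yet measured. It differs from compound 2 by hydrogen in place of methoxy on an aromatic carbon. For the measured compounds named here, the only measured step that bears on this change runs the other way on the same arm: a 2.5-fold lower number from compound 2 to compound 3 (0.40 log units; beyond the scatter), a modest gain on adding a methoxy. Taking a methoxy away from compound 2 is a smaller change, and only one step is available to judge it. A modest move towards a higher number is therefore expected, though a result within the scatter of compound 2 cannot be ruled out.

For compound 4 the expected step is a 1.7-fold higher number from compound 2 to compound 4 (0.22 log units; within the scatter), and the estimate in this assay is 45000 nM, with a range from 18000 nM to 110000 nM.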

Compound 4, concentration for total growth inhibition: 30200 nM
The estimate for compound 4 lay 1.5-fold (0.17 log units) above the measured number; the measured number falls inside the stated range.
By their numbers in this assay, from the lowest: compound 3; then compounds 2 and 4 (each within the scatter of the next); then compound 1.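

In this assay, the change from 3,4-dimethoxyphenyl to 4-methoxyphenyl gives a 1.1-fold higher number from compound 2 to compound 4 (0.05 log units; within the scatter) and so leaves the number unresolved from that of compound 2 at this aromatic carbon, ortho to a methoxy group. The earlier step on the same arm, a 2.5-fold lower number from compound 2 to compound 3 (0.40 log units; beyond the scatter), lay beyond the scatter, whereas this one does not, so the two methoxy changes on the arm do not read alike and a simple count of methoxy groups does not by itself account for the numbers of compounds 2, 3 and 4. No measured evidence accompanies these numbers that could say why the two changes differ.

The compounds shown leave open whether this aromatic carbon tolerates other groups equally, for instance a hydroxyl, a fluorine or an amine in place of the hydrogen of compound 4. They also leave open what happens when the remaining methoxy of compound 4 gives way to hydrogen, which would show whether the arm needs any methoxy at all.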